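The compounds below may be only part of what the source reports. "The series", "measured", "known", "first", "only" and "open" are said of these compounds alone.

Measured compounds:
compound 1, `CCCCS(=O)(=O)n1ccc2c(N(C)C)cccc21`, 49900 nM
compound 2, `CN(C)c1cccc2c1ccn2S(=O)(=O)N1CCCCC1`, 39100 nM
compound 3, `CCCCS(=O)(=O)n1ccc2ccc(-c3ccncc3)cc21`, 1150 nM

All three were tested in an assay on isolated protein for displacement of a labelled ligand from 5-hydroxytryptamine receptor 6 (Homo sapiens), read by scintillation counting, with a stated time of 1 h; on this read-out lower numbers stand for stronger inhibition and higher numbers for weaker inhibition. Compound 1 and compound 2 share a core and differ only at the sulfonyl group: piperidin-1-yl in place of butyl on a sulfonyl sulfur. This change gave a 1.3-fold lower number from compound 1 to compound 2 (0.11 log units; within the scatter), so the two are not told apart by this read-out. Compound 3 has a different core; how its core differs from that of compound 1 is not broken down here. In this assay compound 3 gives a far lower number than either compound 1 or compound 2, so among the three it binds most strongly.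

Compound 4, `O=S(=O)(N1CCCCC1)n1ccc2ccc(-c3ccncc3)cc21`, has not yet been measured. It relates to compound 3 as compound 2 relates to compound 1: piperidin-1-yl in place of butyl on a sulfonyl sulfur. The change and its place are the same as before, so it is the same change on a different core. Because the earlier example gave a 1.3-fold lower number from compound 1 to compound 2 (0.11 log units; within the scatter), a step of similar, small size is expected here, a 1.3-fold lower number from compound 3 to compound 4 (0.11 log units; within the scatter). On that basis compound 4 is estimated to give 900 nM in this assay, with a likely range from 300 nM to 2500 nM.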

Compound 4, inhibition constant: 1660 nM
For compound 4 the middle estimate is 1.8-fold (0.27 log units) below the measured one; measured number inside the range.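

In this assay, putting piperidin-1-yl in place of butyl on the sulfonyl sulfur gave a 1.4-fold higher number from compound 3 to compound 4 (0.16 log units; within the scatter), so the two compounds cannot be told apart by this read-out. The earlier step on the other core looks the same, and the two steps do not differ from each other: the same change on two cores in this assay, a 1.3-fold lower number (0.11 log units; within the scatter) from compound 1 to compound 2 and a 1.4-fold higher number (0.16 log units; within the scatter) from compound 3 to compound 4, 1.8-fold (0.27 log units) apart, within the scatter of two such steps. This shows that, on these two cores, the swap leaves the number unchanged within the scatter, but two cores are too few to make a rule for the series, and a change that has no readable effect on either core cannot show whether a larger effect would carry over.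

The compounds shown leave open whether a different group on the sulfonyl sulfur, such as a phenyl ring, a morpholine ring or a methyl group, would shift the number beyond the scatter. They also leave open whether the match between butyl and piperidin-1-yl would hold on a third core.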